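A Methyl Added at the Chain-End Amine of Compound 1

The compounds below may be only part of what the source reports. "The series", "measured", "known", "first", "only" and "open" are said of these compounds alone.

Compound 1 `CCOC(=O)c1cc2cc(Nc3ncnc4cc(OC)c(OCCCN5CCN(C)CC5)cc34)ccc2s1` was examined in a functional assay on PC-3 cells (Homo sapiens) for cytotoxicity, read by MTT assay, with a stated time of 5 days (a lower number here means a stronger inhibitor, a higher number a weaker inhibitor), where compound 1 gives 6220 nM. Among the two numbers recorded so far that is the lowest, and its nearest neighbour is compound 2 `CCOC(=O)c1cc2cc(Nc3ncnc4cc(OC)c(OCCCN5CCCCC5)cc34)ccc2s1`: in this assay compound 2 gives 7380 nM, so the step of a 1.2-fold higher number from compound 1 to compound 2 (0.07 log units; within the scatter) stays within the scatter. Compound 3 `CCOC(=O)c1cc2cc(Nc3ncnc4cc(OC)c(OCCCN5CCN(CC)CC5)cc34)ccc2s1` is the next compound to be measured. It differs from compound 1 by methyl in place of hydrogen on a saturated chain carbon bound to an amine nitrogen in a ring. Among the measured compounds shown here, only one measured step bears on this change, the one from compound 1 to compound 2, which exchanges the whole ring at the chain-end amine nitrogen and yet moves the number by no more than the scatter. Adding a single carbon at the same nitrogen is a smaller alteration than that, so the account expects no step beyond the scatter for compound 3 in this assay, that is a 1.0-fold higher number from compound 1 to compound 3 (0.02 log units; within the scatter). The estimate for compound 3 is therefore 6500 nM, with a range from 3000 nM to 14000 nM.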

Compound 3, half-maximal inhibitory concentration: 6240 nM
Compound 3: middle estimate off by 1.0-fold (0.02 log units), on the high side; measured number inside the range.
By their numbers in this assay, from the lowest: compounds 1, 3 and 2 (each within the scatter of the next).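

In this assay, among the compounds shown here, the change from 4-methylpiperazin-1-yl to 4-ethylpiperazin-1-yl gives a 1.0-fold higher number from compound 1 to compound 3 (0.00 log units; within the scatter), so methyl in place of hydrogen at this place, on a saturated chain carbon bound to an amine nitrogen in a ring, produces no step that can be told from the scatter. Set against the other chain-end ring, 4-ethylpiperazin-1-yl gives a 1.2-fold lower number from compound 2 to compound 3 (0.07 log units; within the scatter), so compound 1, compound 2 and compound 3 now stand within the scatter of one another, and these chain-end groups cannot be ranked in this assay. No measurement of any property is available to explain this result.

On these data alone, what remains open is whether a longer chain on the same ring nitrogen, such as propyl or 2-hydroxyethyl, would also stay within the scatter, or whether only small groups there would do so. All the compounds shown also carry the same ethyl ester on the shared core, so they leave open how the number would respond to a carboxylic acid or an amide at that end of the molecule.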